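Dropping a Methyl Group on the Pendant Phenyl Ring

A few compounds are considered here, and "the series" means these few. Any claim that something is new, unique, unknown or untested is made for them only; others in the source may bear on it.

Measured so far:
Compound 1, `COc1cc(-c2cc(COCc3cn(Cc4cc(-c5ccccc5)cnc4Cl)nn3)on2)cc(OC)c1OC`, gives 78500 nM in a functional assay on DU-145 cells (Homo sapiens) for cytotoxicity, read by MTT assay, with a stated time of 48 h; a higher number here means a weaker inhibitor, a lower number a stronger inhibitor.
Compound 2, `COc1cc(-c2cc(COCc3cn(Cc4cc(-c5ccc(C)cc5)cnc4Cl)nn3)on2)cc(OC)c1OC`, gives 37300 nM in this assay.
Compound 3, `COc1cc(COCc2cn(Cc3cc(-c4ccc(C)cc4)cnc3Cl)nn2)cc(OC)c1OC`, gives 37000 nM in this assay.

Compound 2 and compound 3 sit together within the usual scatter; the difference between their two cores is not broken down here. Compound 1 differs from compound 2 by hydrogen in place of methyl on an aromatic carbon, and that single change gave a 2.1-fold higher number from compound 2 to compound 1 (0.32 log units; beyond the scatter). The unmeasured compound 4, `COc1cc(COCc2cn(Cc3cc(-c4ccccc4)cnc3Cl)nn2)cc(OC)c1OC`, differs from compound 3 by hydrogen in place of methyl on an aromatic carbon, the same change at the same place, but on the core of compound 3. Among the measured compounds shown here, the step from compound 3 to compound 4 is expected to be a 2.1-fold higher number from compound 3 to compound 4 (0.32 log units; beyond the scatter), because the earlier 2.1-fold higher number from compound 2 to compound 1 (0.32 log units; beyond the scatter) is the only guide for this change. Compound 4 is therefore estimated at 78000 nM in this assay, most likely between 40000 nM and 160000 nM.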

Compound 4, half-maximal inhibitory concentration: 45500 nM
Compound 4: middle estimate off by 1.7-fold (0.23 log units), on the high side; the measured number falls inside the stated range.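

The 4-methylphenyl to phenyl change gives a 1.2-fold higher number from compound 3 to compound 4 (0.09 log units; within the scatter) in this assay. Set beside the earlier step on the other core, this result does not stand apart from it: the same change on two cores in this assay, a 2.1-fold higher number (0.32 log units; beyond the scatter) from compound 2 to compound 1 and a 1.2-fold higher number (0.09 log units; within the scatter) from compound 3 to compound 4, 1.7-fold (0.23 log units) apart, within the scatter of two such steps

So the two cores show no clear difference in how they respond to this change, but only one of the two steps lies beyond the scatter, and two pairs cannot prove that the effect has the same size on both cores or would hold on a third.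

The compounds shown leave open what other groups at the same place on the phenyl ring, such as a chlorine, a methoxy or a carboxylic acid, would do. They also leave open whether a larger change there would separate the two cores.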